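From furan-2-yl to thiophen-2-yl in compound 4

A few compounds are considered here, and "the series" means these few. Any claim that something is new, unique, unknown or untested is made for them only; others in the source may bear on it.

In a functional assay on microsomes for inhibition, with a stated time of 1 h (a higher number here means a weaker inhibitor, a lower number a stronger inhibitor), compound 1 (`CCOC(=O)c1cnn(-c2nc(-c3ccc(OC)cc3)c(C#N)c(=O)n2C)c1N`) reads 68 ug/mL and compound 3 (`CN(C)c1ccc(-c2nc(NN)n(C)c(=O)c2C#N)cc1`) reads 63 ug/mL while compound 2 (`CSc1nc(-c2ccco2)c(C#N)c(=O)n1C`) reads 90 ug/mL on the same scale. Compound 2 therefore stands within the usual scatter of both other compounds, and the three numbers do not separate. Compound 4 (`CSc1nc(-c2cccs2)c(C#N)c(=O)n1C`) carries thiophen-2-yl in place of furan-2-yl on an aromatic carbon. For the measured compounds named here, no measured pair differs in one place, so the data offer no direct precedent for this change. The expected step of a 1.1-fold lower number from compound 2 to compound 4 (0.05 log units; within the scatter) lies within the scatter in this assay and has no clear direction. Compound 4 is estimated at 80 ug/mL with an expected range from 40 ug/mL to 150 ug/mL in this measurement.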

Compound 4, half-maximal inhibitory concentration: 83 ug/mL
Compound 4: the middle estimate sits 1.0-fold (0.02 log units) below what was measured; low and high end bracket the measured number.
By their numbers in this assay, from the lowest: compounds 3, 1, 4 and 2 (each within the scatter of the next).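

In this assay the exchange of furan-2-yl for thiophen-2-yl gives the first one-place comparison, a 1.1-fold lower number from compound 2 to compound 4 (0.04 log units; within the scatter), at the aromatic carbon ortho to a cyano group. At this position, sulfur in place of oxygen in the five-membered aromatic ring does not separate the two compounds. No measurement at hand offers any explanation of this result.

As far as these compounds go, what stays open is whether a group of another kind on this carbon, such as a carboxylic acid, a morpholine ring or a longer alkyl chain, would give a step beyond the scatter.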